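Epoxide analogue of a chalcone amide: cytotoxicity outlook

The source may report more compounds than this note shows. Statements on the series, on what has been measured and on what is new or still open speak of the compounds shown alone.

Compound 1 `CC(C)Cc1ccc(C(=O)/C=C/c2ccc(C(=O)O)cc2)cc1`: < 10 ug/mL
Compound 2 `COC(=O)c1cc(-c2cccc(NC(=O)c3ccc(/C=C/C(=O)c4ccccc4)cc3)c2)on1`: > 50 ug/mL
Compound 3 `COC(=O)c1cc(-c2cccc(NC(=O)c3ccc(/C=C/C(=O)c4ccc(OC)cc4OC)cc3)c2)on1`: > 50 ug/mL

Each of these three values is a limit of the assay, not a measured number. In an ADME assay on Vero cells (Chlorocebus sabaeus) for cytotoxicity, read by MTT assay, with a stated time of 72 h (a higher number here means that more compound is tolerated, a lower number that less compound is tolerated), compound 2 stands at the limit of > 50 ug/mL in this assay, at which 2 of the 3 values shown sit. Compound 4 `COC(=O)c1cc(-c2cccc(NC(=O)c3ccc(C4OC4C(=O)c4ccc(Cl)cc4)cc3)c2)on1` is the unmeasured partner of compound 2; the change is 3-((4-chlorophenyl)carbonyl)oxiran-2-yl in place of 2-benzoylethenyl on an aromatic carbon. Going by the values given here, only one measured step exists, a step that the two limits leave unreadable from compound 2 to compound 3, and it says nothing readable about size or direction; no measured step touches an oxirane or a chlorine. The expectation therefore rests on compound 2 alone, and the step of a number no higher from compound 2 to compound 4 (the limit leaves the size open) is expected to stay within the usual scatter. Compound 4 is expected at 50 ug/mL, within a range from 20 ug/mL to 100 ug/mL.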

Compound 4, half-maximal cytotoxic concentration: > 20 ug/mL
Compound 4: a limit, no number (the forecaster's own chance of this, stated with the estimate: 55%); the middle value lies beyond the limit too.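

Going by these compounds alone, compound 2 and compound 4 both give limits of the assay, not numbers, so no step between them can be read. The compounds shown leave open whether 3-((4-chlorophenyl)carbonyl)oxiran-2-yl in place of 2-benzoylethenyl changes how much compound is tolerated.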